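The source may hold more compounds than are shown below. What is called first, only, known or untested is meant among the compounds shown, and "the series" means these compounds.

Compound 1 `COc1ccc(C(=O)/C=C/c2ccc(F)cc2)c2c1C=CC(C)(C)O2`: > 10000 nM
Compound 2 `COc1ccc(C(=O)/C=C/c2ccc(Br)cc2)c2c1C=CC(C)(C)O2`: > 10000 nM
Compound 3 `COc1ccc(/C=C/C(=O)c2ccc(OC)c3c2OC(C)(C)C=C3)cn1`: > 10000 nM

All three compounds were tested in a functional assay on K562 cells (Homo sapiens) for antiproliferative activity, read by MTT assay, with a stated time of 24 h; on this read-out lower numbers stand for stronger inhibition and higher numbers for weaker inhibition. Each entry is a limit and not a number. In this assay compound 3 gives > 10000 nM, which is a limit. It shares this position with the other two compounds, as the record shows: the limit of > 10000 nM in this assay, at which 3 of the 3 values shown sit. No order can be read among them.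

Compound 4 `COc1ccc(C(=O)/C=C/c2ccco2)c2c1C=CC(C)(C)O2` has not yet been measured. It differs from compound 3 by furan-2-yl in place of 6-methoxypyridin-3-yl on a double-bonded chain carbon bound to a double-bonded chain carbon. In words, it carries furan-2-yl in place of 6-methoxypyridin-3-yl on a double-bonded chain carbon bound to a double-bonded chain carbon.

Going by the values given here, two measured steps touch this same place: a step that the two limits leave unreadable from compound 1 to compound 3 and a step that the two limits leave unreadable from compound 2 to compound 3. A third, a step that the two limits leave unreadable from compound 1 to compound 2, changes only the halogen. None of them has a readable size, so none offers a size to carry over. Among the compounds with values here, still, 4-fluorophenyl, 4-bromophenyl and 6-methoxypyridin-3-yl all end at the same limit, and no compound so far goes against this. No step beyond the scatter is therefore expected, in either direction, and compound 4 will probably also be reported as a limit. The expected change is a step that the limit leaves unreadable from compound 3 to compound 4. For compound 4 the estimated value is 12000 nM, with an expected range from 4000 nM to 30000 nM.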

Compound 4, half-maximal inhibitory concentration: > 10000 nM
Compound 4 was reported as a limit (the forecaster's own chance of this, stated with the estimate: 75%); the middle value does not contradict the limit.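

In this assay compound 4 gives > 10000 nM, which is a limit and not a number. No step can therefore be read between compound 4 and compound 1, compound 2 or compound 3: the limit of > 10000 nM in this assay, at which 4 of the 4 values shown sit.

The compounds shown leave open whether these four differ at all in this assay, and which group at this place, if any, would give a measurable value.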